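The source may report more compounds than this note shows. Statements on the series, on what has been measured and on what is new or still open speak of the compounds shown alone.

Compound 2 `Cc1cccc(N2CCN(c3nc(C(F)(F)F)ccc3CNC(=O)C(C)c3ccc(NS(C)(=O)=O)c(F)c3)CC2)c1` gives 39.2 nM in a functional assay on CHO-K1 cells for antagonist activity at transient receptor potential cation channel subfamily V member 1 (Homo sapiens), read by FLIPR; on this read-out lower numbers stand for stronger inhibition and higher numbers for weaker inhibition. Going by the values given here, of the two compounds measured so far, compound 2 has the lower number: compound 1 `CC1CCC(Nc2nc(C(F)(F)F)ccc2CNC(=O)C(C)c2ccc(NS(C)(=O)=O)c(F)c2)CC1` gives 1130 nM in this assay, a markedly higher number, and that gap lies beyond the usual scatter of repeated measurements. Among the compounds with values here, no pair of measured compounds differs in just one place, so the measured data contain no single step that shows how much a change of one group shifts the read-out. Compound 3 `CC(C(=O)NCc1ccc(C(F)(F)F)nc1N1CCN(Cc2ccccc2)CC1)c1ccc(NS(C)(=O)=O)c(F)c1` differs from compound 2 in one place: benzyl in place of 3-methylphenyl on an amine nitrogen in a ring. The same atoms are present in both, joined differently. Within the data shown here, with no measured step of this kind to lean on, only a cautious expectation can be given, and a modest rise in the number, that is a somewhat weaker inhibition, is expected a 3.1-fold higher number from compound 2 to compound 3 (0.49 log units; beyond the scatter). Compound 3 is therefore estimated to give about 120 nM in this assay, with a likely range from 30 nM to 600 nM.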

Compound 3, half-maximal inhibitory concentration: 634 nM
Compound 3: the middle estimate sits 5.3-fold (0.72 log units) below what was measured, and the stated range ends below it.
By their numbers in this assay, from the lowest: compound 2; then compounds 3 and 1 (each within the scatter of the next).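

Changing to benzyl in place of 3-methylphenyl on an amine nitrogen in a ring gives a 16-fold higher number from compound 2 to compound 3 (1.21 log units; beyond the scatter) in this assay, so inhibition becomes clearly weaker. The two groups hold the same atoms and the same six-membered aromatic ring of carbon only, so at this position a large shift goes with how that ring is joined to the nitrogen, not with which atoms are present. The compounds shown include no measurement that explains the size of this shift.

From the compounds shown here alone, it remains open how much the methyl group of compound 2 contributes, a question that a plain phenyl on the same nitrogen would address. Also open, going by these compounds, is how a longer link, as in phenylethyl, would compare with benzyl.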